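Swapping a substituted phenyl for furan-2-yl

The source may report more compounds than this note shows. Statements on the series, on what has been measured and on what is new or still open speak of the compounds shown alone.

Compound 1 `COc1cc(-c2cccc3nc(-c4ccc(Br)cc4)oc23)cc(OC)c1OC` gives > 25000 nM (a limit, not a number)
Compound 2 `COc1cc(-c2nc3cccc(-c4cc(OC)c(OC)c(OC)c4)c3o2)ccc1O` gives 10300 nM

Within the data shown here, in a functional assay on U-251 cells (Homo sapiens) for antiproliferative activity, read by MTT assay, with a stated time of 48 h (a higher number here means a weaker inhibitor, a lower number a stronger inhibitor), compound 2 gives 10300 nM as the only true number so far. Compound 1 sits at > 25000 nM as a limit of the assay, not a number.

Compound 3 `COc1cc(-c2cccc3nc(-c4ccco4)oc23)cc(OC)c1OC` keeps the shared core and differs from compound 2 in one place: furan-2-yl in place of 4-hydroxy-3-methoxyphenyl on an aromatic carbon (furan-2-yl in place of 4-hydroxy-3-methoxyphenyl).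

Among the measured compounds shown here, the one measured step at this place is an at least 2.4-fold lower number from compound 1 to compound 2 (0.38 log units; beyond the scatter) and it is the only guide available. One end of that step is the limit of > 25000 nM in this assay, at which 1 of the 2 values shown sits, and not a true number. Compound 3 gives up the group that compound 2 gained in an at least 2.4-fold lower number from compound 1 to compound 2 (0.38 log units; beyond the scatter) and so a higher number, meaning a weaker inhibitor, is expected in this assay for the new compound. For the measured compounds named here, no furan-2-yl compound has been measured yet, which leaves the size uncertain. The estimated change is a 1.9-fold higher number from compound 2 to compound 3 (0.29 log units; within the scatter) on this reasoning. For compound 3 the estimate is 20000 nM with an expected range from 8000 nM to 50000 nM and the assay may again report only a limit.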

Compound 3, half-maximal inhibitory concentration: 10600 nM
Compound 3: the middle estimate sits 1.9-fold (0.28 log units) above what was measured; the range from low to high includes it.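

Replacing 4-hydroxy-3-methoxyphenyl with furan-2-yl at this position gives a 1.0-fold higher number from compound 2 to compound 3 (0.01 log units; within the scatter), so in this assay these two groups cannot be told apart. The group that enters is a five-membered aromatic ring with 5 heavy atoms and 0 hydrogen-bond donors, while the one that leaves is a six-membered aromatic ring with 9 heavy atoms and 1 hydrogen-bond donor, so between compound 2 and compound 3 neither the larger ring nor its donor is needed to hold this level of activity. Furan-2-yl also gives an at least 2.3-fold lower number from compound 1 to compound 3 (0.37 log units; beyond the scatter), which shows that the gain over 4-bromophenyl does not depend on a substituted phenyl, though the true size of that gain stays unknown, as the value of compound 1 is a limit and not a number: the limit of > 25000 nM in this assay, at which 1 of the 3 values shown sits.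

The compounds shown leave open whether a much smaller group such as methyl, or a group of another kind such as an amine or a carboxylic acid, would move the number beyond the scatter at this position. They also leave open whether any group here can bring a large gain in activity, since the two true numbers shown lie within the scatter of each other.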